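Lengthening a Side Chain on a Shared Core

This account rests on a few compounds, and the source may have more. Where it says the series, first, only, none or still open, it means among the compounds named here.

Compound 1 `Nc1ccc(-c2cc(=O)c3c(N)c(F)c(C(=O)O)c(F)c3o2)cc1F` carries a carboxy group on an aromatic carbon of the shared core. In a functional assay on MCF7 cells (Homo sapiens) for cytotoxicity, read by neutral red uptake, with a stated time of 3 days (on this read-out higher numbers stand for weaker inhibition and lower numbers for stronger inhibition), compound 1 gives only a limit, > 10000 nM, so no number is known for it. Compound 2 `CN(C)CCCC(=O)OCc1c(F)c(N)c2c(=O)cc(-c3ccc(N)c(F)c3)oc2c1F` replaces that carboxy with a (((3-(dimethylamino)propyl)carbonyl)oxy)methyl group and gives 29 nM in this assay, a change of an at least 340-fold lower number from compound 1 to compound 2 (2.53 log units; beyond the scatter). Compound 3 `COCc1c(F)c(N)c2c(=O)cc(-c3ccc(N)c(F)c3)oc2c1F` carries a methoxymethyl group instead and gives 46 nM in this assay, a change of an at least 210-fold lower number from compound 1 to compound 3 (2.33 log units; beyond the scatter). Between the two the step is a 1.6-fold higher number from compound 2 to compound 3 (0.20 log units; within the scatter), so the numbers of compound 2 and compound 3 lie within the usual scatter of each other, and compound 3 stands beside compound 2 rather than apart from it.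

Compound 4 `CCCOCc1c(F)c(N)c2c(=O)cc(-c3ccc(N)c(F)c3)oc2c1F` is the next step: ethyl in place of hydrogen on a saturated chain carbon bound to an oxygen on a saturated carbon. Among the compounds with values here, the only measured step that bears on this part of the molecule is a 1.6-fold higher number from compound 2 to compound 3 (0.20 log units; within the scatter), where a far larger change at the oxygen on a saturated carbon left the number within the scatter. A small ethyl extension is therefore expected to change little, and the step is estimated as a 1.1-fold higher number from compound 3 to compound 4 (0.04 log units; within the scatter), nothing beyond the scatter in either direction. Compound 4 is expected to give roughly 50 nM in this assay, with a likely range from 18 nM to 140 nM.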

Compound 4, half-maximal inhibitory concentration: 1200 nM
For compound 4 the middle estimate is 24-fold (1.38 log units) below the measured one; the whole stated range lies below it.
By their numbers in this assay, from the lowest: compounds 2 and 3 (each within the scatter of the next); then compound 4. At a limit, above all of these: compound 1.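

Within the data shown here, the oxygen on a saturated carbon is less forgiving than the earlier compounds suggested: swapping its methyl for propyl gives a 26-fold higher number from compound 3 to compound 4 (1.42 log units; beyond the scatter) in this assay, a large loss from a small addition. Size alone does not order these compounds, since compound 2, with its bigger (3-(dimethylamino)propyl)carbonyl group on that oxygen, goes against any simple rule that a longer group gives a higher number, and the step to the propyl group reads a 41-fold higher number from compound 2 to compound 4 (1.62 log units; beyond the scatter) on the same read-out. Compound 4 nevertheless keeps a clear gap to the carboxy compound, with an at least 8.3-fold lower number from compound 1 to compound 4 (0.92 log units; beyond the scatter) as the step, which rests on a limit for compound 1 and so gives only the smallest possible size of that gap.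

An ethyl or butyl group on this oxygen would show whether the number climbs steadily with chain length or jumps at one point, and a propyl chain ending in a dimethylamino group, without the carbonyl, would show whether that amine is what sets compound 2 apart. Nothing measured here gives a reason for the loss seen with the propyl group.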